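This account rests on a few compounds, and the source may have more. Where it says the series, first, only, none or still open, it means among the compounds named here.

In a functional assay on cells (Cancer cell lines, Homo sapiens) for cytotoxicity, read by sulforhodamine B assay, with a stated time of 48 h (a higher number here means a weaker inhibitor of growth, a lower number a stronger inhibitor of growth), three compounds have been measured:
Compound 1, `O=C1N=C(N2N=C(c3ccccc3)CC2c2ccccc2O)S/C1=C1/C(=O)Nc2ccccc21`, gives 17800 nM.
Compound 2, `COc1ccc(C2CC(c3ccccc3)=NN2C2=NC(=O)/C(=C3\C(=O)Nc4ccccc43)S2)cc1`, gives 4270 nM.
Compound 3, `CN(C)c1ccc(C2CC(c3ccccc3)=NN2C2=NC(=O)/C(=C3\C(=O)Nc4ccccc43)S2)cc1`, gives 18800 nM.

The numbers of compound 3 and compound 1 lie within the scatter of each other, whereas a 4.4-fold higher number from compound 2 to compound 3 (0.64 log units; beyond the scatter) lies beyond it. Compound 4, `CN(C)c1ccc(C2CC(c3ccccc3)=NN2C2=NC(=O)/C(=C3\C(=O)Nc4ccc(Cl)cc43)S2)cc1`, differs from compound 3 only by chloro in place of hydrogen on an aromatic carbon. Among the compounds with values here, no measured step touches this part of the shared core: the steps of a 4.2-fold lower number from compound 1 to compound 2 (0.62 log units; beyond the scatter) and a 1.1-fold higher number from compound 1 to compound 3 (0.02 log units; within the scatter) concern the group on the saturated ring carbon, not the fused ring. With nothing to guide the direction, the change is expected to leave the number roughly where it stands, so for compound 4 the estimated step is a 1.3-fold lower number from compound 3 to compound 4 (0.10 log units; within the scatter), giving 15000 nM, within 4000 nM to 55000 nM.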

Compound 4, concentration for total growth inhibition: 430 nM
The estimate for compound 4 lay 35-fold (1.54 log units) above the measured number, and the stated range ends above it.
By their numbers in this assay, from the lowest: compound 4; then compound 2; then compounds 1 and 3 (each within the scatter of the next).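

In this assay, the aromatic carbon of the fused ring proves a highly sensitive position: chloro in place of hydrogen gives a 44-fold lower number from compound 3 to compound 4 (1.64 log units; beyond the scatter). The earlier steps shown here changed only the group on the saturated ring carbon, and none approaches this size. No available evidence explains the gain.

As far as these compounds go, whether fluoro, bromo or a methyl group at this carbon would act like chloro remains open. So does whether chloro would bring a similar step alongside the 4-methoxyphenyl group of compound 2.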